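The source may hold more compounds than are shown below. What is called first, only, known or untested is meant among the compounds shown, and "the series" means these compounds.

Measured in a functional assay on HCT-116 cells (Homo sapiens) for cytotoxicity, read by MTT assay; a lower number here means a stronger inhibitor, a higher number a weaker inhibitor:
- compound 1 `Nc1ccccc1NC(=O)c1ccc(CNc2nc3ccccc3[nH]2)cc1`: 300 nM
- compound 2 `Nc1ccccc1NC(=O)c1ccc(CNc2nc3cc(Cl)ccc3o2)cc1`: 200 nM
- compound 3 `Nc1ccccc1NC(=O)c1ccc(CSc2nc3ccc(NCc4ccccn4)cc3s2)cc1`: 1000 nM

Compound 3 carries the highest number of the three in this assay and so is the weakest inhibitor here, with compound 1 and compound 2 both lying lower by more than the scatter. The next compound, compound 4 `Nc1ccccc1NC(=O)c1ccc(CSc2nc3ccc(NCc4cccnc4)cc3s2)cc1`, keeps everything in compound 3 except one group, with pyridin-3-yl in place of pyridin-2-yl on a saturated chain carbon bound to a nitrogen on an aromatic ring.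

Going by the values given here, no two measured compounds differ in one place only, so the data give no direct measure of what this change does. With so little to go on, the expectation stays anchored on compound 3 at 1000 nM, and no shift beyond the scatter is expected. The expected step, a 1.4-fold lower number from compound 3 to compound 4 (0.15 log units; within the scatter), is therefore small and its direction uncertain. For compound 4 the estimated value is 700 nM, with an expected range of 250 nM to 2000 nM.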

Compound 4, half-maximal inhibitory concentration: 1000 nM
Compound 4: the middle estimate sits 1.4-fold (0.15 log units) below what was measured, within the range that was stated.
By their numbers in this assay, from the lowest: compounds 2 and 1 (each within the scatter of the next); then compounds 3 and 4 (each within the scatter of the next).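

Going by these compounds alone, the exchange of pyridin-2-yl for pyridin-3-yl on a saturated chain carbon bound to a nitrogen on an aromatic ring gives the first single-place comparison: in this assay it shows no change at the digits printed from compound 3 to compound 4 (within the scatter). At this position, the two pyridinyl attachments are therefore not told apart by this read-out, although one step on one cell line cannot show more than that. No supporting measurement bears on this result.

From the compounds shown here alone, whether pyridin-4-yl, an unsubstituted phenyl or a morpholine at the same place would separate from compound 3 remains open. Compound 1 and compound 2 each differ from compound 3 in more than one place, so the contributions of those separate differences cannot be read.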